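The source may report more compounds than this note shows. Statements on the series, on what has been measured and on what is new or still open speak of the compounds shown alone.

Measured so far:
- compound 1 `OC[C@H]1OC(n2cnc3c(-c4ccco4)ncnc32)[C@H](O)[C@@H]1O`: 2700 nM
- compound 2 `OC[C@H]1OC(n2cnc3c(-c4cc[nH]c4)ncnc32)[C@H](O)[C@@H]1O`: 3200 nM

In a functional assay on HL-60 cells (Homo sapiens) for inhibition (on this read-out higher numbers stand for weaker inhibition and lower numbers for stronger inhibition), compound 1 gives 2700 nM, and compound 2 gives 3200 nM. Compound 1 stands alongside compound 2 rather than apart from it: the step of a 1.2-fold higher number from compound 1 to compound 2 (0.07 log units; within the scatter) falls within the scatter, so the two cannot be told apart. That step is the only one known, and it swaps one five-membered aromatic ring for another at the same position of the shared core.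

Compound 3 `Cc1csc(-c2ncnc3c2ncn3C2O[C@H](CO)[C@@H](O)[C@H]2O)c1` is not yet measured. It differs from compound 1 by 4-methylthiophen-2-yl in place of furan-2-yl on an aromatic carbon. This is again a swap of one five-membered aromatic ring for another at the same place, with a methyl added. Among the compounds with values here, the one known step of that kind, a 1.2-fold higher number from compound 1 to compound 2 (0.07 log units; within the scatter), stayed within the scatter, so no step beyond the scatter is expected here either; the expected step is no change at the digits printed from compound 1 to compound 3 (within the scatter). Compound 3 is therefore estimated at 2700 nM, with a range from 1200 nM to 6500 nM.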

Compound 3, half-maximal inhibitory concentration: 5600 nM
Beside the measured number, compound 3's estimate is 2.1-fold (0.32 log units) below it; the measured number falls inside the stated range.
By their numbers in this assay, from the lowest: compounds 1, 2 and 3 (each within the scatter of the next, the first and the last beyond it).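

This position on the shared core does respond to the ring placed on it, if only modestly: in this assay, 4-methylthiophen-2-yl in place of furan-2-yl gives a 2.1-fold higher number from compound 1 to compound 3 (0.32 log units; beyond the scatter) and so marks the first shift here toward weaker inhibition that exceeds the scatter. Set against the 1H-pyrrol-3-yl group, the same ring gives a 1.8-fold higher number from compound 2 to compound 3 (0.24 log units; within the scatter) and leaves compound 2 inseparable from both compound 1 and compound 3. No independent measurements are available to explain the shift.

The methyl group and the change of ring arrive together, and no thiophen-2-yl without the methyl is among the compounds shown to separate the two. Also open, as far as these compounds go, is how this position would respond to a phenyl ring or an amine in place of these five-membered rings.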